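The source may hold more compounds than are shown below. What is called first, only, known or untested is meant among the compounds shown, and "the series" means these compounds.

This study asks whether a set of compounds harm human liver-derived cells, judged in an ADME assay on Huh-7 cells (Homo sapiens) for cytotoxicity, with a stated time of 72 h; on this read-out lower numbers stand for higher toxicity in this test and higher numbers for lower toxicity in this test. Compound 1, `CS(=O)(=O)Nc1ccc2c(c1)S(=O)(=O)N=C(c1c(O)c(-c3ccc(Cl)s3)nn(CCC3CC3)c1=O)N2`, gives only a limit of the assay, > 33000 nM. Compound 2, `CC(C)CCn1nc(-c2ccccc2)c(O)c(C2=NS(=O)(=O)c3cc(NS(C)(=O)=O)ccc3N2)c1=O`, likewise gives only a limit of the assay, > 1000 nM. The two limits sit at different levels, so neither compound can be placed above the other. The next compound, compound 3, `CCC(C)(C)c1nn(CCC(C)C)c(=O)c(C2=NS(=O)(=O)c3cc(NS(C)(=O)=O)ccc3N2)c1O`, differs from compound 2 by one change: 1,1-dimethylpropyl in place of phenyl on an aromatic carbon. Going by the values given here, with no measured step to lean on, the expected step that the limit leaves unreadable from compound 2 to compound 3 is none beyond the usual scatter. Compound 3 is therefore estimated at 3000 nM, between 1000 nM and 10000 nM, most likely reported again only as a limit.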

Compound 3, half-maximal cytotoxic concentration: > 1000 nM
Compound 3 gave a limit, no number; the forecaster's own chance of this, stated with the estimate: 70%; the middle value is on the limit's open side.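

Going by these compounds alone, compound 2 and compound 3 each give only a limit, so no step from one to the other can be read. The compounds shown leave open at what concentration any of them would actually harm these cells.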